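The source may hold more compounds than are shown below. What is called first, only, known or untested is meant among the compounds shown, and "the series" means these compounds.

Compound 1 `N#C/C(=C\c1cn(Cc2ccc(Cl)cc2)c2ccccc12)C(=O)c1c[nH]c2ccccc12` is the parent of this small series. In a functional assay on PC-3 cells (Homo sapiens) for cytotoxicity, read by WST assay, with a stated time of 24 h (on this read-out higher numbers stand for weaker inhibition and lower numbers for stronger inhibition), compound 1 gives > 50000 nM, which is a limit of the assay rather than a number. Compound 2 `N#C/C(=C\c1cn(Cc2ccc(Cl)cc2)c2ccc(Br)cc12)C(=O)c1c[nH]c2ccccc12` gives 47100 nM in this assay, and the step of an at least 1.0-fold lower number from compound 1 to compound 2 (0.02 log units; that floor lies within the scatter) is the only readable one. Compound 3 `COc1ccc(Cn2cc(/C=C(\C#N)C(=O)c3c[nH]c4ccccc34)c3ccccc32)cc1` gives > 50000 nM, again a limit. The step that the two limits leave unreadable from compound 1 to compound 3 therefore cannot be sized. Both unreadable values rest on (the limit of > 50000 nM in this assay, at which 2 of the 3 values shown sit). Compound 4 `N#C/C(=C\c1cn(Cc2ccc(Cl)cc2)c2ccccc12)C(=O)c1c[nH]c2cc(F)ccc12` differs from compound 1 by fluoro in place of hydrogen on an aromatic carbon. Among the measured compounds shown here, with only one small step and two limits as guides, the change from compound 1 to compound 4 is expected to give no shift beyond the scatter, so compound 4 is estimated at 50000 nM (range 20000 nM to 100000 nM), with the step of a number no higher from compound 1 to compound 4 (the limit leaves the size open) expected.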

Compound 4, half-maximal inhibitory concentration: > 50000 nM
Compound 4: a limit, no number; the forecaster's own chance of this, stated with the estimate: 65%; the middle value lies on the limit itself.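

Compound 4 gives > 50000 nM in this assay, which is a limit and not a number. Among the compounds shown here, compound 1 also stands at a limit, so no step between compound 1 and compound 4 can be read. The compounds shown leave open what fluoro in place of hydrogen does to the read-out.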